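Cinnamoyl amide replacing a tetrahydronaphthoyl group in a bisindole series

The source may hold more compounds than are shown below. What is called first, only, known or untested is meant among the compounds shown, and "the series" means these compounds.

Measured compounds:
- Compound 1, `CN1[C@@H]2c3[nH]c4ccccc4c3C[C@H]1[C@H](C#N)N1[C@@H](CNC(=O)c3cccc(C(F)(F)F)c3)c3[nH]c4ccccc4c3C[C@@H]21`, gives 110 nM in a functional assay on MCF7 cells (Homo sapiens) for cytotoxicity, read by MTT assay, with a stated time of 72 h; on this read-out higher numbers stand for weaker inhibition and lower numbers for stronger inhibition.
- Compound 2, `CN1[C@@H]2c3[nH]c4ccccc4c3C[C@H]1[C@H](C#N)N1[C@@H](CNC(=O)c3cccc4c3CCCC4)c3[nH]c4ccccc4c3C[C@@H]21`, gives 4470 nM in this assay.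
- Compound 3, `CN1[C@@H]2c3[nH]c4ccccc4c3C[C@H]1[C@H](C#N)N1[C@@H](CNC(=O)c3ccc4ccccc4c3)c3[nH]c4ccccc4c3C[C@@H]21`, gives 4650 nM in this assay.

Compound 2 stands second highest of the three numbers in this assay. Its nearest neighbour is compound 3, with a 1.0-fold higher number from compound 2 to compound 3 (0.02 log units; within the scatter), a gap within the scatter; the furthest is compound 1, which gives the lowest number of the set, a 41-fold higher number from compound 1 to compound 2 (1.61 log units; beyond the scatter).

Compound 4, `CN1[C@@H]2c3[nH]c4ccccc4c3C[C@H]1[C@H](C#N)N1[C@@H](CNC(=O)/C=C/c3ccccc3)c3[nH]c4ccccc4c3C[C@@H]21`, is not yet measured. It differs from compound 2 in one place: 2-phenylethenyl in place of 1,2,3,4-tetrahydronaphthalen-5-yl on a carbonyl carbon.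

Among the compounds with values here, two measured steps touch the same carbonyl carbon. The move from a single aromatic ring carrying trifluoromethyl to a bicyclic group, a 41-fold higher number from compound 1 to compound 2 (1.61 log units; beyond the scatter), was large. The exchange of one bicyclic group for another, a 1.0-fold higher number from compound 2 to compound 3 (0.02 log units; within the scatter), changed nothing beyond the scatter. Compound 4 returns to a single aromatic ring, but reached through a double bond rather than directly, with no trifluoromethyl. The data therefore point toward a lower number than compound 2, but only compound 1 supports a large recovery, and its trifluoromethyl is absent here. In this assay compound 4 is expected to give 1800 nM, within 400 nM to 7000 nM, an estimated step of a 2.5-fold lower number from compound 2 to compound 4 (0.40 log units; beyond the scatter).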

Compound 4, half-maximal inhibitory concentration: 7190 nM
For compound 4 the middle estimate is 4.0-fold (0.60 log units) below the measured one, outside the stated range (above it).
By their numbers in this assay, from the lowest: compound 1; then compounds 2, 3 and 4 (each within the scatter of the next).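

In this assay the 2-phenylethenyl amide falls in with the two bicyclic amides, with a 1.6-fold higher number from compound 2 to compound 4 (0.21 log units; within the scatter) and a 1.5-fold higher number from compound 3 to compound 4 (0.19 log units; within the scatter), so at this carbonyl carbon a single six-membered aromatic ring reached through a double bond does not bring back the value of compound 1. The distance to the 3-(trifluoromethyl)phenyl amide stays large, with a 65-fold higher number from compound 1 to compound 4 (1.82 log units; beyond the scatter), and among these four compounds only compound 1 stands apart, so having one aromatic ring rather than two is not enough to account for that gap. No measurement shown here gives a reason for the gap.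

From the compounds shown here alone, it remains open whether the trifluoromethyl or the direct attachment of the ring to the carbonyl carbon carries the difference, and a phenyl directly on the carbonyl carbon, or a trifluoromethyl on the phenyl of the 2-phenylethenyl group, would separate the two. Also open, going by these compounds, is how a saturated chain in place of the double bond, or an amine or a carboxylic acid on the phenyl ring, would read in this assay.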